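The source may hold more compounds than are shown below. What is called first, only, known or untested is meant among the compounds shown, and "the series" means these compounds.

An account of cytotoxicity in a small series of triazenes

The series was examined in an ADME assay on BHK-21 cells (Mesocricetus auratus) for cytotoxicity, read by MTT assay, with a stated time of 96 h; on this read-out higher numbers stand for lower toxicity in this test and lower numbers for higher toxicity in this test. Compound 1, with the structure `Fc1ccc(F)c(/N=N/Nc2ccccc2)c1`, sits at a limit of the assay, giving > 100000 nM in this assay, a value that is a limit rather than a number. Compound 2, with the structure `CN(C)CCCN(/N=N/c1cc(F)ccc1F)c1ccccc1`, gives 25000 nM in this assay. Compound 3, with the structure `CN(C)CCCN(/N=N/c1ccccc1)c1cccc(C(F)(F)F)c1`, gives 49000 nM in this assay; the values of compound 2 and compound 3 lie within the scatter of each other, and the difference between the two cores is not broken down here.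

Among the measured compounds shown here, the one measured change, (hydrogen in place of 3-(dimethylamino)propyl on a nitrogen on an aromatic ring), gives an at least 4.0-fold higher number from compound 2 to compound 1 (0.60 log units; beyond the scatter). That this step is an at-least figure follows from the limit of > 100000 nM in this assay, at which 1 of the 3 values shown sits.

Compound 4, with the structure `FC(F)(F)c1cccc(N/N=N/c2ccccc2)c1`, is not yet measured. It differs from compound 3 by hydrogen in place of 3-(dimethylamino)propyl on a nitrogen on an aromatic ring, the same change as that from compound 2 to compound 1, made on a nitrogen whose surroundings are described in identical words in both cases.

On the strength of the measured step, the change is expected to give a 3.1-fold higher number from compound 3 to compound 4 (0.49 log units; beyond the scatter) in this assay. Compound 4 is therefore expected to give about 150000 nM in this assay, with a likely range from 60000 nM to 400000 nM, and a substantial chance that only a limit is returned.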

Compound 4, half-maximal cytotoxic concentration: > 100000 nM
Compound 4: a limit, no number; the forecaster's own chance of this, stated with the estimate: 65%; the middle value is on the limit's open side.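

Replacing 3-(dimethylamino)propyl with hydrogen on the core of compound 3 again leaves the higher number in this assay, an at least 2.0-fold higher number from compound 3 to compound 4 (0.30 log units; that floor lies within the scatter), so the change points the same way on both cores, although this second step is not shown to go beyond the scatter. Set beside the earlier step, this shows agreement in direction across these two pairs, but it does not show that the change has the same size on each core: the same change on two cores in this assay, an at least 4.0-fold higher number (0.60 log units; beyond the scatter) from compound 2 to compound 1 and an at least 2.0-fold higher number (0.30 log units; that floor lies within the scatter) from compound 3 to compound 4; the limit leaves it open whether they differ. As far as these compounds go, neither step has a measured end point, and the true size of the change therefore remains unknown in both cases: the limit of > 100000 nM in this assay, at which 2 of the 4 values shown sit.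

The compounds shown compare only the whole 3-(dimethylamino)propyl group with hydrogen, so they leave open whether the lower numbers go with the tertiary amine or with the chain itself, a question that a plain propyl chain, a shorter or longer chain bearing the same amine, or a chain ending in a carboxylic acid could address. They also leave open how compound 1 and compound 4 compare with each other, and whether the same direction would hold on any core beyond these two.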